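Propyl in place of methoxy at an oral dose

A few compounds are considered here, and "the series" means these few. Any claim that something is new, unique, unknown or untested is made for them only; others in the source may bear on it.

Of the compounds shown here, two built on a shared core have been tested in a functional assay on the whole organism with Rattus norvegicus as the target, at a dose of 0.3 mg/kg by the oral route; a lower number here means a weaker effect, a higher number a stronger effect of the compound at the dose given. Compound 1 `COc1cccc(-c2cc(Cl)cc(C(=O)Nc3nn[nH]n3)n2)c1` carries a methoxy group on an aromatic carbon, and in this assay compound 1 gives 32%. Compound 2 `COc1ccc(-c2cc(Cl)cc(C(=O)Nc3nn[nH]n3)n2)cc1` carries its methoxy group on an aromatic carbon as well, and in this assay compound 2 gives 40%. The number for compound 2 is nominally the higher of the two, but the gap to compound 1 lies within the usual scatter of such measurements, so the two compounds cannot be ranked against each other.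

Compound 3 `CCCc1ccc(-c2cc(Cl)cc(C(=O)Nc3nn[nH]n3)n2)cc1` has not yet been measured in this assay. Compared with compound 2 it differs in one place: propyl in place of methoxy on an aromatic carbon. Within the data shown here, no measured pair in this set shows what such a change does to the read-out, so the expectation rests only on the narrow spread of the two known values. The step from compound 2 to compound 3 is therefore expected to be none beyond the scatter, as expressed by a number 2 percentage points lower from compound 2 to compound 3 (within the scatter). On that basis compound 3 is estimated at 38% in this assay, with a range from 15% to 62%.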

Compound 3, a percentage reported as inhibition, in the whole organism at one dose (the size of the read-out at that dose, not a potency): 42%
Beside the measured number, compound 3's estimate is 4 percentage points below it; measured number inside the range.
By their numbers in this assay, from the lowest: compounds 1, 2 and 3 (each within the scatter of the next).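

In this assay, among these compounds, the change of methoxy to propyl on an aromatic carbon para to a large group gives a number 2 percentage points higher from compound 2 to compound 3 (within the scatter), and this is the first step in the set that isolates a single change at this place. A group holding an oxygen and a hydrogen-bond acceptor gives way to an all-carbon chain with no hydrogen-bond acceptor, yet the read-out stays within the scatter, so in this pair the oxygen of the methoxy group is not required for the effect seen at this dose. Nothing measured here explains this result.

Among the compounds shown here, it remains open whether a longer chain such as hexyl, a carboxylic acid or an amine at this place would give a read-out beyond the scatter of the one for compound 3. Also open, going by these compounds, is whether compound 2 and compound 3 would remain within the scatter of each other at other doses, as the read-out gives the size of the effect at a single oral dose and not a potency.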